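Carbonyl substituent exchange in the piperazine amide series

The source may hold more compounds than are shown below. What is called first, only, known or untested is meant among the compounds shown, and "the series" means these compounds.

In an assay on isolated protein for inhibition of aldehyde dehydrogenase 1A1 (Homo sapiens), read by spectrophotometry, tested at 10 uM (a lower number here means less inhibition, a higher number more inhibition at the concentration tested (going by the name of the read-out)), compound 1 `CC(C)=CCn1c(CN2CCN(C(=O)C3CC3)CC2)nc2ccccc21` gives 74.3%. Compound 2 `Cc1cccc(Cn2c(CN3CCN(C(=O)c4cccnc4)CC3)nc3ccccc32)c1` gives 24.5% in this assay, the lowest of the two numbers in hand; compound 1 stands higher than compound 2 by a margin beyond the scatter. Among the compounds with values here, no pair of measured compounds differing in one place is available, so no measured step exists to anchor a prediction.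

Compound 3 `Cc1cccc(Cn2c(CN3CCN(C(=O)c4ccc(C(F)(F)F)cc4)CC3)nc3ccccc32)c1` has not yet been measured. It differs from compound 2 by 4-(trifluoromethyl)phenyl in place of pyridin-3-yl on a carbonyl carbon. Nothing measured bears directly on this change, so the direction is open; a small rise is expected, of a size that may stay within the scatter, and the expected step in this assay is a number 10.5 percentage points higher from compound 2 to compound 3 (beyond the scatter). Compound 3 is estimated at 35% in this assay, with an expected range from 10% to 65%.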

Compound 3, a percentage reported as inhibition, at one concentration (the size of the read-out at that concentration, not a potency): 22.9%
Estimate against measurement, compound 3: 12.1 percentage points above; the range from low to high includes it.
By their numbers in this assay, from the lowest: compounds 3 and 2 (each within the scatter of the next); then compound 1.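

In this assay, within the data shown here, 4-(trifluoromethyl)phenyl in place of pyridin-3-yl on the carbonyl carbon gives a number 1.6 percentage points lower from compound 2 to compound 3 (within the scatter), the first step that can be read at a single place. With the rest of compound 2 held constant, the two aromatic groups are not told apart at this position, although one ring has a hetero atom and the other is carbon only and carries trifluoromethyl. No measurement at hand offers an explanation for this result.

Compound 1 differs from compound 2 in more than one place, so it gives no reading of the carbonyl substituent alone. On these data alone, whether a carboxylic acid or an aminomethyl group on the aromatic ring at this carbonyl would shift the inhibition remains open.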